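This account rests on a few compounds, and the source may have more. Where it says the series, first, only, none or still open, it means among the compounds named here.

Working notes on the series in a functional assay on HL-60 cells (Homo sapiens) for inhibition, read by MTT assay, with a stated time of 72 h; on this read-out lower numbers stand for stronger inhibition and higher numbers for weaker inhibition.

Compound 1 `Cc1nc(-c2ccc(F)cc2)c(C(=O)N2CCN(c3cccc(Cl)c3)CC2)o1` gives 40.1 nM, the lowest of the three numbers. Compound 2 `Cc1ccc(C)c(N2CCN(C(=O)c3oc(C)nc3-c3ccc(F)cc3)CC2)c1` gives 358 nM, and compound 3 `COc1cccc(N2CCN(C(=O)c3oc(C)nc3-c3ccc(F)cc3)CC2)c1` gives 112 nM. The recorded steps all vary the aryl group on the amine nitrogen in the ring: an 8.9-fold higher number from compound 1 to compound 2 (0.95 log units; beyond the scatter), a 2.8-fold higher number from compound 1 to compound 3 (0.45 log units; beyond the scatter) and a 3.2-fold lower number from compound 2 to compound 3 (0.50 log units; beyond the scatter), each modest and each beyond the scatter.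

Compound 4 `Cc1nc(-c2ccccc2Cl)c(C(=O)N2CCN(c3cccc(Cl)c3)CC2)o1` changes a different place, the aryl on the five-membered ring: 2-chlorophenyl in place of 4-fluorophenyl on an aromatic carbon. Among the measured compounds shown here, no measured step touches this position, so the three steps give no direction for it. The number for compound 4 is therefore expected near that of compound 1, with a wide range, estimated at 80 nM between 20 nM and 400 nM, a step of a 2.0-fold higher number from compound 1 to compound 4 (0.30 log units; within the scatter).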

Compound 4, half-maximal inhibitory concentration: 132 nM
Estimate against measurement, compound 4: 1.7-fold (0.22 log units) below; measured number inside the range.
By their numbers in this assay, from the lowest: compound 1; then compounds 3 and 4 (each within the scatter of the next); then compound 2.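

The aryl on the five-membered ring matters in this assay: with the 3-chlorophenyl on the amine nitrogen unchanged, 2-chlorophenyl in place of 4-fluorophenyl gives a 3.3-fold higher number from compound 1 to compound 4 (0.52 log units; beyond the scatter) and this lies beyond the scatter. This first step at the position is modest, like the steps on the amine-bound aryl group. No measurement offers a reason for the change.

This single step alters both the halogen and its place on the phenyl, and the compounds shown do not separate the two. 4-Chlorophenyl or 2-fluorophenyl at this position remains open, as does a phenyl bearing an amine or a carboxylic acid.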